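A few compounds are considered here, and "the series" means these few. Any claim that something is new, unique, unknown or untested is made for them only; others in the source may bear on it.

Going by the values given here, in a functional assay on cells for agonist activity at Free fatty acid receptor 1 (Homo sapiens), read by FLIPR and calcium flux, with a stated time of 100 s (on this read-out lower numbers stand for an effect already at smaller amounts and higher numbers for an effect only at larger amounts of compound), compound 1 `Cc1ccccc1Oc1ccc(N2C[C@@H](C(F)(F)F)C[C@H]2CC(=O)O)cc1` gives 73 nM, the lowest of the two numbers measured so far, though compound 2 `Cc1ccccc1Oc1ccc(N2CCC[C@H]2CC(=O)O)cc1` stands within the scatter of it at 74 nM. Among the compounds with values here, the single measured step, a 1.0-fold higher number from compound 1 to compound 2 (0.01 log units; within the scatter), concerns the saturated ring and left the read-out essentially unchanged. Compound 3 `O=C(O)C[C@@H]1C[C@H](C(F)(F)F)CN1c1ccc(Oc2ccccc2C(F)(F)F)cc1` departs from compound 1 in a different way: trifluoromethyl in place of methyl on an aromatic carbon. Within the data shown here, no measured step in this set touches that aromatic group, so nothing here shows directly how this assay answers to an exchange at that place. Among the measured compounds shown here, the only precedent, a 1.0-fold higher number from compound 1 to compound 2 (0.01 log units; within the scatter), shows a trifluoromethyl exchanged elsewhere without a shift beyond the scatter, which hints weakly that the read-out is not easily disturbed, but it is not the same change, and the wider uncertainty of an untested position has to be carried into the estimate. The expected step is therefore modest, a 1.1-fold higher number from compound 1 to compound 3 (0.04 log units; within the scatter), with no clear direction. Compound 3 is estimated at 80 nM, within a range from 30 nM to 250 nM.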

Compound 3, half-maximal effective concentration: 310 nM
Beside the measured number, compound 3's estimate is 3.9-fold (0.59 log units) below it; the whole stated range lies below it.
By their numbers in this assay, from the lowest: compounds 1 and 2 (each within the scatter of the next); then compound 3.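

In this assay the aromatic carbon ortho to a large group responds to the exchange of methyl for trifluoromethyl, with the step to 2-(trifluoromethyl)phenyl reading (a 4.2-fold higher number from compound 1 to compound 3 (0.63 log units; beyond the scatter)). Going by these compounds alone, the only earlier step (a 1.0-fold higher number from compound 1 to compound 2 (0.01 log units; within the scatter)) concerned a saturated ring carbon and stayed within the scatter, so this is the first step in the set to go beyond it, and it shows that exchanging a trifluoromethyl group does not leave the read-out unchanged at every place in these compounds. Nothing at hand bears on what lies behind this shift.

The compounds shown leave open whether the step at the aromatic carbon would be of similar size on the core of compound 2, which carries hydrogen on the saturated ring carbon. They also leave open how that aromatic carbon would respond to plain hydrogen, chlorine, a methoxy group or a nitrile in place of methyl, and so whether the change seen with compound 3 is particular to trifluoromethyl.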